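The compounds below may be only part of what the source reports. "The series", "measured", "known", "first", "only" and "open" are said of these compounds alone.

Compound 1 `CCCCOc1ccc(-c2c(C)[nH]c(=O)n2C)cc1`: 5100 nM
Compound 2 `CCCCOc1ccc(-c2c(C)[nH]c(=O)n2C2CCCCC2)cc1`: 13900 nM
Compound 3 `CCCCCCOc1ccc(-c2c(C)[nH]c(=O)n2C)cc1`: 7300 nM

In a functional assay on brain (Rattus norvegicus, strain Wistar) for inhibition (a lower number here means a stronger inhibitor, a higher number a weaker inhibitor), compound 2 gives 13900 nM, and compound 3 gives 7300 nM, two values within the scatter of each other. Compound 2 does stand apart from compound 1, with a 2.7-fold higher number from compound 1 to compound 2 (0.44 log units; beyond the scatter), for cyclohexyl in place of methyl on an aromatic nitrogen. Compound 4 `CCCc1ccc(-c2c(C)[nH]c(=O)n2C2CCCCC2)cc1` keeps that cyclohexyl and differs from compound 2 at the other end of the molecule: propyl in place of butoxy on an aromatic carbon.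

For the measured compounds named here, no measured step makes this exchange, so the evidence is indirect. Going by the values given here, the only measured change to the butoxy chain, ethyl in place of hydrogen on a saturated chain carbon, gave a 1.4-fold higher number from compound 1 to compound 3 (0.16 log units; within the scatter), which lies within the scatter. On that limited basis, no step beyond the scatter is expected in this assay, in either direction, though the uncertainty is wide. The estimate means an expected 1.1-fold higher number from compound 2 to compound 4 (0.03 log units; within the scatter). For compound 4 the estimated value is 15000 nM, with an expected range from 5000 nM to 45000 nM.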

Compound 4, half-maximal inhibitory concentration: 13900 nM
For compound 4 the middle estimate is 1.1-fold (0.03 log units) above the measured one, and the stated range covers the measured number.
By their numbers in this assay, from the lowest: compounds 1, 3, 2 and 4 (each within the scatter of the next, the first and the last beyond it).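

In this assay, propyl in place of butoxy on the aromatic carbon gives no change at the digits printed from compound 2 to compound 4 (within the scatter). The earlier step at this position lengthened the chain and kept the oxygen on the aromatic ring, with methyl on the aromatic nitrogen. This step removes that oxygen, with its one hydrogen-bond acceptor, and shortens the group from 5 heavy atoms to 3 with cyclohexyl on the nitrogen, yet the reading stays within the scatter. Nothing available explains why the two compounds read alike.

The compounds shown leave open whether the same exchange would read alike with methyl rather than cyclohexyl on the aromatic nitrogen. They also leave open how this position would respond to an amine or a carboxylic acid in place of the propyl chain.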